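Leaving the 2,4-dimethoxyphenyl group: compound 3 to compound 4

The source may hold more compounds than are shown below. What is called first, only, known or untested is meant among the compounds shown, and "the series" means these compounds.

Compound 1 `COc1cccc(CNc2ncnc3c2ncn3[C@@H]2O[C@H](CO)[C@@H](O)[C@H]2O)c1`: 7600 nM
Compound 2 `COc1cccc(CNc2ncnc3c2ncn3[C@@H]2O[C@H](CO)[C@@H](O)[C@H]2O)c1OC`: > 166000 nM (a limit)
Compound 3 `COc1ccc(CNc2ncnc3c2ncn3[C@@H]2O[C@H](CO)[C@@H](O)[C@H]2O)c(OC)c1`: > 166000 nM (a limit)

In a functional assay on CCRF-CEM cells (Homo sapiens) for antiproliferative activity, with a stated time of 72 h (a higher number here means a weaker inhibitor, a lower number a stronger inhibitor), compound 1 gives 7600 nM and is the only one of the three with a true number. Compound 2 gives > 166000 nM, which is a limit of the assay. Compound 3 gives > 166000 nM, which is also a limit and not a number. Compound 3 therefore stands at the limit of > 166000 nM in this assay, at which 2 of the 3 values shown sit, and has no readable position of its own.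

Compound 4 `OC[C@H]1O[C@@H](n2cnc3c(NCc4ccc(F)c(Cl)c4)ncnc32)[C@H](O)[C@@H]1O` differs from compound 3 by 3-chloro-4-fluorophenyl in place of 2,4-dimethoxyphenyl on a saturated chain carbon bound to a nitrogen on an aromatic ring and has not yet been measured. Among the measured compounds shown here, two measured steps bear on this change. They are an at least 21-fold higher number from compound 1 to compound 3 (1.33 log units; beyond the scatter) and an at least 21-fold higher number from compound 1 to compound 2 (1.33 log units; beyond the scatter), and both end in a limit. For the measured compounds named here, the step between the two dimethoxy compounds cannot be read, and no measured compound carries a halogen. Compound 4 has no dimethoxyphenyl group, so the nearest guide is compound 1 at 7600 nM, though this comparison is uncertain. What is expected in this assay is an at least 16-fold lower number from compound 3 to compound 4 (1.22 log units; beyond the scatter), an estimated large step to a lower number. Compound 4 is expected at 10000 nM, with an estimated range from 1500 nM to 100000 nM.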

Compound 4, half-maximal inhibitory concentration: 3400 nM
Estimate against measurement, compound 4: 2.9-fold (0.47 log units) above; the measured number falls inside the stated range.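

In this assay, the 3-chloro-4-fluorophenyl group on the saturated chain carbon bound to a nitrogen on an aromatic ring restores a readable number where both dimethoxyphenyl groups had lost it, with an at least 48-fold lower number from compound 3 to compound 4 (1.68 log units; beyond the scatter) and an at least 48-fold lower number from compound 2 to compound 4 (1.68 log units; beyond the scatter). Compound 2 and compound 3 each stand at a limit of the assay and not at a number, so these two steps give only a minimum size: the limit of > 166000 nM in this assay, at which 2 of the 4 values shown sit. Among the compounds shown here, the change from the single methoxy group also counts as beyond the scatter, with a 2.2-fold lower number from compound 1 to compound 4 (0.35 log units; beyond the scatter), so at this place a ring carrying two halogens, and no oxygen, gives a lower number than the 3-methoxyphenyl group, although the step is modest.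

The compounds shown leave open whether the chlorine or the fluorine accounts for this step, as neither 3-chlorophenyl nor 4-fluorophenyl stands among them. They also leave open whether 3,4-dimethoxyphenyl would end at a limit like the other two dimethoxyphenyl groups, or whether a 3-methoxy-4-fluorophenyl group, which joins features of compound 1 and compound 4, would give a readable number.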